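Swapping a bromophenyl for a pyridyl on a sulfamate core

The source may report more compounds than this note shows. Statements on the series, on what has been measured and on what is new or still open speak of the compounds shown alone.

Measured so far:
- Compound 1, `CCN(Cc1cccc(Br)c1)c1ccc(C(=O)N2CCc3ccc(OS(N)(=O)=O)cc3C2)cc1`: 97.2%
- Compound 2, `CC(C)CCN(CCC(C)C)c1cccc(C(=O)N2CCc3ccc(OS(N)(=O)=O)cc3C2)c1`: 75.9%

In an assay on HEK293 cells for inhibition of Steryl-sulfatase (Homo sapiens), tested at 1 uM (a higher number here means a stronger effect of the compound at the concentration tested, a lower number a weaker effect), compound 1 gives the higher of the two numbers; compound 2 sits well below it, beyond the scatter. Compound 3, `CCN(Cc1ccncc1)c1ccc(C(=O)N2CCc3ccc(OS(N)(=O)=O)cc3C2)cc1`, has not been measured. It differs from compound 1 in one place: pyridin-4-yl in place of 3-bromophenyl on a saturated chain carbon bound to a nitrogen on an aromatic ring. Among the measured compounds shown here, no measured pair shows this kind of change, so the expected step rests only on the two numbers above. The step of a number 7.2 percentage points lower from compound 1 to compound 3 (within the scatter) is expected to be small, downward at most, and likely within the scatter. Compound 3 is estimated at 90%, between 70% and 99%.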

Compound 3, a percentage reported as inhibition, at one concentration (the size of the read-out at that concentration, not a potency): 86.6%
The estimate for compound 3 lay 3.4 percentage points above the measured number; the measured number falls inside the stated range.
By their numbers in this assay, from the lowest: compound 2; then compound 3; then compound 1.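

In this assay, replacing 3-bromophenyl with pyridin-4-yl costs a modest amount, a number 10.6 percentage points lower from compound 1 to compound 3 (beyond the scatter), so this place on the molecule does respond to the change of ring. Even so, compound 3 keeps a high read-out of 86.6%, which shows that bromine is not needed for a strong effect at the concentration tested. Nothing available gives a reason for the drop.

As far as these compounds go, whether the drop follows the loss of the bromine or the arrival of the ring nitrogen stays open. An unsubstituted phenyl at this place would help separate the two.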